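The source may hold more compounds than are shown below. What is called first, only, known or untested is meant among the compounds shown, and "the series" means these compounds.

Values in a functional assay on B16 cells (Mus musculus) for inhibition; a lower number here means a stronger inhibitor, a higher number a weaker inhibitor:
- Compound 1 `CC(C)CN(CC(=O)NN(Cc1ccccc1)c1cnccn1)NC(=O)CBr`: 11400 nM
- Compound 2 `CC(C)CN(CC(=O)N(CC(C)C)NC(=O)OCc1ccccc1)NC(=O)CNNC(=O)CBr`: 2500 nM
- Compound 3 `CC(C)CN(CC(=O)N(Cc1ccccc1)NC(=O)OCc1ccccc1)/N=C/c1ccccc1B(O)O`: 33500 nM
- Compound 4 `CC(C)CN(CC(=O)N(CC(C)C)NC(=O)OCc1ccccc1)/N=C/c1cccc(B(O)O)c1`: not yet measured

Compound 2 gives the lowest of the three numbers, 2500 nM, and its gaps to compound 1 and compound 3 both lie beyond the scatter. It is therefore the strongest inhibitor measured so far.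

Compound 4 differs from compound 2 in one place, on an amine nitrogen: a group of 11 heavy atoms (7 carbon, 1 boron, 1 nitrogen, 2 oxygen; one six-membered aromatic ring of carbon only) in place of a group of 10 heavy atoms (4 carbon, 3 nitrogen, 2 oxygen, 1 bromine; no ring), on an amine nitrogen. The group that leaves holds the bromine, and the group that enters holds the boron. Among the measured compounds shown here, no pair of measured compounds isolates this change, so the evidence is indirect. For the measured compounds named here, the only measured compound with boron is compound 3, at 33500 nM, a weaker result than either compound with bromine. Compound 3 also differs from compound 2 elsewhere, so this comparison is only a rough guide.

The expected step is an 8.0-fold higher number from compound 2 to compound 4 (0.90 log units; beyond the scatter), toward weaker inhibition and beyond the scatter. For compound 4 the estimated value is 20000 nM, with an expected range of 6000 nM to 60000 nM.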

Compound 4, half-maximal inhibitory concentration: 53900 nM
Beside the measured number, compound 4's estimate is 2.7-fold (0.43 log units) below it, and the stated range covers the measured number.
By their numbers in this assay, from the lowest: compound 2; then compound 1; then compounds 3 and 4 (each within the scatter of the next).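

In this assay, the change on the amine nitrogen gives a 22-fold higher number from compound 2 to compound 4 (1.33 log units; beyond the scatter), a large step toward weaker inhibition. Among the compounds shown here, with the rest of the molecule held the same, this shows that the group at this position strongly affects the result, something the earlier compounds could not show because they differed in more than one place. No supporting measurement here explains the loss.

The group that enters differs from the one that leaves in several ways at once, including boron for bromine and an aromatic ring for no ring, so the step cannot be assigned to any one of them. The same aromatic ring carrying a carboxylic acid in place of the boron-containing part would help separate the role of the ring from that of the boron.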